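The source may hold more compounds than are shown below. What is called first, only, known or untested is meant among the compounds shown, and "the series" means these compounds.

Measured in a functional assay on NCI-H460 cells (Homo sapiens) for cytotoxicity, read by MTT assay, with a stated time of 68 h; on this read-out higher numbers stand for weaker inhibition and lower numbers for stronger inhibition:
- compound 1 `O=C(Nc1cccc(-c2cccc(F)c2)c1)C(Cl)Cl`: > 50000 nM (a limit, not a number)
- compound 2 `CCOc1cccc(-c2cc(NC(=O)C(Cl)Cl)cc(-c3cccc(OCC)c3)c2)c1`: 4950 nM

Not yet measured: compound 3 `O=C(Nc1cccc(-c2cccc(C(F)(F)F)c2)c1)C(Cl)Cl`.

Compound 1 stands at the limit of this assay, with > 50000 nM as its only entry. Compound 3 keeps the core of compound 1, with trifluoromethyl in place of fluoro on an aromatic carbon, meta to a large group (trifluoromethyl in place of fluoro on an aromatic carbon). Among the measured compounds shown here, no measured step between two close analogues is available to size this change. For the measured compounds named here, only compound 2, at 4950 nM, gives a number so far. A small move towards stronger inhibition is expected, or none that can be resolved, and a reading at the limit remains likely. The expected step of an at least 1.6-fold lower number from compound 1 to compound 3 (0.22 log units; that floor lies within the scatter) is therefore modest. For compound 3 the estimated value is 30000 nM, with an expected range from 10000 nM to 70000 nM.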

Compound 3, half-maximal inhibitory concentration: 30200 nM
The estimate for compound 3 lay 1.0-fold (0.00 log units) below the measured number, and the stated range covers the measured number.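

In this assay compound 1 gives > 50000 nM, which is a limit and not a number. With trifluoromethyl in place of fluoro on this aromatic carbon, the step is an at least 1.6-fold lower number from compound 1 to compound 3 (0.21 log units; that floor lies within the scatter), and compound 3 gives the core of compound 1 its first actual number. The step can be read only as a floor because one of its ends is a limit: the limit of > 50000 nM in this assay, at which 1 of the 3 values shown sits.

Going by these compounds, the true size of the change therefore stays open, including whether it goes beyond the scatter. Also open, on these data alone, is what a methoxy group, a nitrile or an amine on the same aromatic carbon would do, since a single pair cannot show whether the number follows the group's size or some other feature of it.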